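A Fluoro to Methoxy Swap on the Fused Core

This account rests on a few compounds, and the source may have more. Where it says the series, first, only, none or still open, it means among the compounds named here.

Of the compounds shown here, two have so far been measured in an assay on CHO-TREX cells for antagonist activity at transient receptor potential cation channel subfamily A member 1 (Homo sapiens), read by FLIPR and calcium flux, with a stated time of 10 min; on this read-out lower numbers stand for stronger inhibition and higher numbers for weaker inhibition. Compound 1 `CC(C)c1ccccc1-c1ccc2[nH]ncc2c1` gives 514 nM. Compound 2 `Fc1cc2[nH]ncc2cc1-c1ccccc1C(F)(F)F` gives 48 nM. Among the measured compounds shown here, on these two numbers compound 2 stands lowest: its only neighbour, compound 1, sits at a higher number, and that gap lies beyond the usual scatter of repeated measurements, so compound 2 is the stronger inhibitor of the pair.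

Compound 3 `COc1cc2[nH]ncc2cc1-c1ccccc1C(F)(F)F` has not yet been measured. It differs from compound 2 in one place: methoxy in place of fluoro on an aromatic carbon. For the measured compounds named here, no pair of measured compounds differs by a change of this kind, so there is no measured step to lean on. A small group giving way to a somewhat larger one may move the number either way; a modest rise, or no change beyond the scatter, is the expectation here. The step from compound 2 to compound 3 is expected to be a 1.9-fold higher number from compound 2 to compound 3 (0.27 log units; within the scatter). Compound 3 is therefore estimated at 90 nM, with a likely range from 25 nM to 350 nM.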

Compound 3, half-maximal inhibitory concentration: 26 nM
Compound 3: middle estimate off by 3.5-fold (0.54 log units), on the high side; low and high end bracket the measured number.
By their numbers in this assay, from the lowest: compounds 3 and 2 (each within the scatter of the next); then compound 1.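

In this assay, methoxy in place of fluoro on this aromatic carbon, ortho to a large group, gives a 1.8-fold lower number from compound 2 to compound 3 (0.27 log units; within the scatter) and so leaves the two compounds indistinguishable on this read-out. Among the compounds shown here, this is the first measured sign that the position accepts more than one group: methoxy, with 2 heavy atoms and 1 hydrogen-bond acceptor, and fluoro, with 1 heavy atom and 0 hydrogen-bond acceptors, give numbers within the scatter of each other, something compound 1 and compound 2 could not show, as they differ in more than one place. Nothing measured here explains why the two groups give such similar numbers.

Still open, as far as these compounds go, is whether larger or different groups at this carbon, such as an ethoxy chain, an amine or a carboxylic acid, would keep the number in the same range or move it beyond the scatter. Also open, from the compounds shown here alone, is whether methoxy would give a similar number if the trifluoromethyl group of compound 3 gave way to another group, such as a nitrile.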